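The source may hold more compounds than are shown below. What is called first, only, known or untested is meant among the compounds shown, and "the series" means these compounds.

Compound 1 `O=CCN1N=C(c2ccc3ccccc3c2)CC1c1ccccc1` gives 21500 nM in a functional assay on OVCAR cells (Homo sapiens) for cytotoxicity, read by sulforhodamine B assay, with a stated time of 48 h; on this read-out higher numbers stand for weaker inhibition and lower numbers for stronger inhibition.
Compound 2 `COc1ccc(C2CC(c3ccc4ccccc4c3)=NN2CC=O)cc1O` gives 2160 nM in this assay.

Compound 2 stands lowest of the two numbers, with compound 1 as the nearest and higher one. Compound 3 `O=CCN1N=C(c2ccc3ccccc3c2)CC1c1ccco1` differs from compound 2 by furan-2-yl in place of 3-hydroxy-4-methoxyphenyl on a saturated ring carbon. Among the compounds with values here, only one measured step bears on an exchange of the aryl group on this saturated ring carbon: it brought a 10-fold lower number from compound 1 to compound 2 (1.00 log units; beyond the scatter). Within the data shown here, because a 10-fold lower number from compound 1 to compound 2 (1.00 log units; beyond the scatter) accompanied the arrival of the 3-hydroxy-4-methoxyphenyl group, its departure in compound 3 is expected to push the number back upward, while furan-2-yl itself has no measured counterpart here, so the size of the step is uncertain. Compound 3 is accordingly expected to give about 10000 nM, with a range from 3000 nM to 40000 nM. This estimate corresponds to a 4.6-fold higher number from compound 2 to compound 3 (0.67 log units; beyond the scatter) as the expected step.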

Compound 3, half-maximal inhibitory concentration: 18000 nM
Estimate against measurement, compound 3: 1.8-fold (0.26 log units) below, and the stated range covers the measured number.
By their numbers in this assay, from the lowest: compound 2; then compounds 3 and 1 (each within the scatter of the next).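

In this assay, furan-2-yl in place of 3-hydroxy-4-methoxyphenyl on the saturated ring carbon gave an 8.3-fold higher number from compound 2 to compound 3 (0.92 log units; beyond the scatter), so the lower number seen earlier does not survive the departure of that group. Furan-2-yl in place of phenyl gave a 1.2-fold lower number from compound 1 to compound 3 (0.08 log units; within the scatter), so these two aromatic rings cannot be told apart at this position. Of the three groups shown here, only 3-hydroxy-4-methoxyphenyl stands apart, which the single earlier step could not show: exchanging phenyl for another aromatic ring does not by itself bring a lower number.

From the compounds shown here alone, it remains open whether the hydroxy or the methoxy part of that group carries the difference, and what a dimethylamino group on the phenyl ring or a longer chain in place of the formylmethyl group would give. No measurement at hand explains these steps.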